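Adding methylsulfanyl to the acetamido group of compound 2

A few compounds are considered here, and "the series" means these few. Any claim that something is new, unique, unknown or untested is made for them only; others in the source may bear on it.

In a functional assay (aorta) with Rattus norvegicus as the target (on this read-out lower numbers stand for an effect already at smaller amounts and higher numbers for an effect only at larger amounts of compound), two compounds sharing the core have been measured. Compound 1 (`C/N=C(/NC)Nc1nc(-c2ccc(OC)cc2)c(-c2ccc(OC)cc2)s1`) gives (2.4 uM) and compound 2 (`COc1ccc(-c2nc(CNC(C)=O)sc2-c2ccc(OC)cc2)cc1`) gives (8.1 uM), so compound 2 holds the higher of the two numbers. The next compound, compound 3 (`COc1ccc(-c2nc(CNC(=O)CSC)sc2-c2ccc(OC)cc2)cc1`), differs from compound 2 by one change (methylsulfanyl in place of hydrogen on a saturated chain carbon bound to a carbonyl carbon): methylsulfanyl in place of hydrogen on a saturated chain carbon bound to a carbonyl carbon, which turns acetamido into (((methylsulfanyl)methyl)carbonyl)amino. Among the compounds with values here, only one measured step bears on this (a 3.4-fold higher number from compound 1 to compound 2 (0.53 log units; beyond the scatter)). It is modest, though beyond the scatter, and it exchanged a whole group on an aromatic carbon. Within the data shown here, the new change falls inside the group that entered in that step, and no measured compound carries methylsulfanyl, so that step gives neither a size nor a direction for it. No step beyond the scatter is therefore expected in this assay, and the estimated step is small (a 1.2-fold lower number from compound 2 to compound 3 (0.06 log units; within the scatter)). For compound 3 the expected value is 7 uM with an estimated range from 2.5 uM to 20 uM in this read-out.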

Compound 3, concentration for half-maximal effect: 6 uM
Beside the measured number, compound 3's estimate is 1.2-fold (0.07 log units) above it, within the range that was stated.
By their numbers in this assay, from the lowest: compound 1; then compounds 3 and 2 (each within the scatter of the next).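

In this assay, putting methylsulfanyl in place of hydrogen on a saturated chain carbon bound to a carbonyl carbon gives a 1.4-fold lower number from compound 2 to compound 3 (0.13 log units; within the scatter). Within the data shown here, this is the first measured change inside the acetamido group, and it shows that this chain carbon can carry methylsulfanyl without a difference that this read-out can separate from the scatter. The exchange of the whole group on the aromatic carbon still gives a 2.5-fold higher number from compound 1 to compound 3 (0.40 log units; beyond the scatter), so compound 3, like compound 2, stays apart from compound 1, and the added methylsulfanyl does not close that gap; no evidence is available that explains either step.

From the compounds shown here alone, whether the same chain carbon would accept an amine, a carboxylic acid or a longer chain on the sulfur without a step beyond the scatter remains open, as does whether methoxy would read the same as methylsulfanyl. Also open, going by these compounds, is whether methylsulfanyl would give a similarly small step on a group of the kind carried by compound 1.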